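The source may hold more compounds than are shown below. What is called first, only, known or untested is meant among the compounds shown, and "the series" means these compounds.

Measured compounds:
- compound 1 `COc1cc(Cn2cc(CNC(=O)c3cn(-c4ccccc4)nc3-c3ccc(Cl)cc3)nn2)cc(OC)c1OC`: 100 nM
- compound 2 `COc1ccc(-c2nn(-c3ccccc3)cc2C(=O)NCc2cn(Cc3ccc(F)cc3)nn2)cc1`: 500 nM
- compound 3 `COc1ccc(-c2nn(-c3ccccc3)cc2C(=O)NCc2cn(Cc3ccc(C(F)(F)F)cc3)nn2)cc1`: 6200 nM

In a functional assay on HeLa cells (Homo sapiens) for antiproliferative activity, read by sulforhodamine B assay, with a stated time of 48 h (a higher number here means a weaker inhibitor of growth, a lower number a stronger inhibitor of growth), compound 3 gives the highest number of the three measured. Its nearest neighbour is compound 2, from which it is separated by a 12-fold higher number from compound 2 to compound 3 (1.09 log units; beyond the scatter); the furthest is compound 1.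

Compound 4 `COc1ccc(-c2nn(-c3ccccc3)cc2C(=O)NCc2cn(Cc3cc(OC)c(OC)c(OC)c3)nn2)cc1` is not yet measured. It differs from compound 3 by 3,4,5-trimethoxyphenyl in place of 4-(trifluoromethyl)phenyl on a saturated chain carbon bound to an aromatic nitrogen. For the measured compounds named here, the only measured step bearing on this position is the one from compound 2 to compound 3, which was large and showed that the group on this chain carbon moves the number well beyond the scatter. Going by the values given here, compound 1 also carries a 3,4,5-trimethoxyphenyl at the same place and gives 100 nM, though its core differs from that of compound 4 in the group on the other aromatic ring, and no step for that pair is on hand; it shows only that the trimethoxy group sits in the most active compound measured.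

A large step downward is therefore expected in this assay from compound 3 to compound 4, a 25-fold lower number from compound 3 to compound 4 (1.39 log units; beyond the scatter). Compound 4 is estimated at 250 nM, with a range from 60 nM to 1200 nM.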

Compound 4, concentration for 50% growth inhibition: 1700 nM
The estimate for compound 4 lay 6.8-fold (0.83 log units) below the measured number; the measured number lies above the stated range.
By their numbers in this assay, from the lowest: compound 1; then compound 2; then compound 4; then compound 3.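

In this assay, the group on the saturated chain carbon bound to an aromatic nitrogen now has three examples on the shared core, and they give separate values: 3,4,5-trimethoxyphenyl brings a 3.6-fold lower number from compound 3 to compound 4 (0.56 log units; beyond the scatter) but still gives a 3.4-fold higher number from compound 2 to compound 4 (0.53 log units; beyond the scatter), so this group sits on neither side of the pair formed by 4-fluorophenyl and 4-(trifluoromethyl)phenyl. The low number of compound 1 does not come from the 3,4,5-trimethoxyphenyl alone: with that group held constant, methoxy in place of chloro on an aromatic carbon gives a 17-fold higher number from compound 1 to compound 4 (1.23 log units; beyond the scatter), the largest of the three new steps, so the other aromatic ring also weighs heavily on the number. No measurement here accounts for either effect.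

For the compounds shown here, whether 4-fluorophenyl and 4-(trifluoromethyl)phenyl would keep their order relative to 3,4,5-trimethoxyphenyl on the core of compound 1 remains open, as that core appears here with only one group at the chain carbon. Also open, going by these compounds, is how an amine or a carboxylic acid on the phenyl ring at this place, or a longer chain leading to that ring, would behave.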